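Acetamide to Methanesulfonamide on a Shared Core

The source may report more compounds than this note shows. Statements on the series, on what has been measured and on what is new or still open speak of the compounds shown alone.

Compound 2 `CC(=O)N(C)C[C@@H]1CCCc2cc(S(=O)(=O)c3cccc(F)c3)ccc21` holds the lower of the two numbers seen so far: in an assay on isolated protein for displacement of a labelled ligand from 5-hydroxytryptamine receptor 6 (Homo sapiens) (on this read-out lower numbers stand for stronger inhibition and higher numbers for weaker inhibition), compound 2 gives 1.59 nM. Within the data shown here, compound 1 `O=C(NC[C@@H]1CCCc2cc(S(=O)(=O)c3cccc(F)c3)ccc21)c1ccc[nH]1` gives 5.01 nM, and the step of a 3.2-fold lower number from compound 1 to compound 2 (0.50 log units; beyond the scatter) is the only measured step that touches this position. Compound 3 `CS(=O)(=O)NC[C@@H]1CCCc2cc(S(=O)(=O)c3cccc(F)c3)ccc21` differs from compound 2 by methanesulfonamido in place of acetyl(methyl)amino on a saturated chain carbon bound to a saturated ring carbon. That earlier step swapped a different pair of groups, so it offers only a rough guide. Compound 3 is therefore expected to show only a modest shift, a 2.0-fold higher number from compound 2 to compound 3 (0.30 log units; within the scatter). Compound 3 is estimated at 3.2 nM, within 1 nM to 10 nM.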

Compound 3, inhibition constant: 0.2 nM
Compound 3: middle estimate off by 16-fold (1.20 log units), on the high side; the measured number lies below the stated range.
By their numbers in this assay, from the lowest: compound 3; then compound 2; then compound 1.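

On a saturated chain carbon bound to a saturated ring carbon, methanesulfonamido in place of acetyl(methyl)amino gives an 8.0-fold lower number from compound 2 to compound 3 (0.90 log units; beyond the scatter) and puts compound 3 lowest of the three. Methylsulfonyl in place of (1H-pyrrol-2-yl)carbonyl on the amine nitrogen gives a 25-fold lower number from compound 1 to compound 3 (1.40 log units; beyond the scatter) and shows that this position can carry a sulfonyl group as well as a carbonyl group. Nothing available here accounts for the gain. Going by these compounds, it remains open whether ethylsulfonyl, a longer chain on the sulfonyl, would hold this number, or whether a methyl on the sulfonamide nitrogen would.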